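Para substituent swap on the benzyl thioether arm

This account rests on a few compounds, and the source may have more. Where it says the series, first, only, none or still open, it means among the compounds named here.

Measured so far:
compound 1 `Cc1cc(Nc2ccn(Cc3cccc4ccccc34)n2)n2nc(SCc3ccc(Br)cc3)nc2n1`, 3240 nM in a functional assay on MGC-803 cells (Homo sapiens) for inhibition, read by MTT assay, with a stated time of 72 h; on this read-out higher numbers stand for weaker inhibition and lower numbers for stronger inhibition
compound 2 `CCCCCc1c(C)nc2nc(SCc3ccc(Cl)cc3)nn2c1Nc1cc(-c2ccccc2)[nH]n1`, 7140 nM
compound 3 `Cc1cc(Nc2cc(-c3ccccc3)[nH]n2)n2nc(SCc3ccc(F)cc3)nc2n1`, 3270 nM

Compound 3 sits in the middle of the three values. Its number and that of compound 1 lie within the scatter of each other, so no order between them can be read. Compound 2 shows a higher number, beyond the scatter, though compound 2 and compound 3 differ in several places, so only the two values themselves can be compared.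

Compound 4 `COc1ccc(CSc2nc3nc(C)cc(Nc4cc(-c5ccccc5)[nH]n4)n3n2)cc1` differs from compound 3 in one place: methoxy in place of fluoro on an aromatic carbon. Going by the values given here, no measured pair shows this swap. Given that fluoro and bromo at the same spot gave values within the scatter, the step of a 1.1-fold higher number from compound 3 to compound 4 (0.03 log units; within the scatter) is expected to be small, with no clear direction. Compound 4 is therefore estimated at 3500 nM, within 1500 nM to 8500 nM.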

Compound 4, half-maximal inhibitory concentration: 3170 nM
Estimate against measurement, compound 4: 1.1-fold (0.04 log units) above; the measured number falls inside the stated range.
By their numbers in this assay, from the lowest: compounds 4, 1 and 3 (each within the scatter of the next); then compound 2.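

In this assay, going by these compounds alone, the change from 4-fluorobenzyl to 4-methoxybenzyl gives a 1.0-fold lower number from compound 3 to compound 4 (0.01 log units; within the scatter) and is the first comparison that differs in one place. On this aromatic carbon, with the shared core held fixed, methoxy and fluoro cannot be told apart, although methoxy adds a hydrogen-bond acceptor. No measured evidence bears on this result.

As far as these compounds go, whether an amine, a carboxylic acid or a longer chain such as ethoxy on this carbon would give a step beyond the scatter stays open. Also open, from the compounds shown here alone, is whether the swap would read the same on the cores of compound 1 and compound 2.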